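A few compounds are considered here, and "the series" means these few. Any claim that something is new, unique, unknown or untested is made for them only; others in the source may bear on it.

In a functional assay on MCF7 cells (Homo sapiens) for cytotoxicity, read by MTT assay, with a stated time of 72 h (a higher number here means a weaker inhibitor, a lower number a stronger inhibitor), compound 1 (`O=C(/C=C/c1ccc([N+](=O)[O-])cc1)Nc1cc2c(Nc3ccc(F)c(Cl)c3)ncnc2cc1O[C@H]1CCOC1`) gives 26700 nM and compound 2 (`COc1ccc(OC)c(/C=C/C(=O)Nc2cc3c(Nc4ccc(F)c(Cl)c4)ncnc3cc2OC)c1`) gives 34300 nM while compound 3 (`COc1ccc(OC)c(/C=C/C(=O)Nc2cc3c(Nc4ccc(F)c(Cl)c4)ncnc3cc2O[C@H]2CCOC2)c1`) gives 36300 nM in the same run of numbers; compound 2 thus stands within the scatter of both others. The move to compound 4 (`COc1cc2ncnc(Nc3ccc(F)c(Cl)c3)c2cc1NC(=O)/C=C/c1ccc(C#N)cc1`) is 4-cyanophenyl in place of 2,5-dimethoxyphenyl on a double-bonded chain carbon bound to a double-bonded chain carbon with the shared core unchanged. The closest measured change is a 1.4-fold higher number from compound 1 to compound 3 (0.13 log units; within the scatter) on exchanging 4-nitrophenyl for 2,5-dimethoxyphenyl at the same place, and it lies within the scatter. The oxygen substituent change, a 1.1-fold higher number from compound 2 to compound 3 (0.02 log units; within the scatter) for oxolan-3-yl in place of methyl, also lies within it. In this assay no step beyond the scatter is therefore expected. The expected size is a 1.2-fold lower number from compound 2 to compound 4 (0.07 log units; within the scatter) on this estimate. Compound 4 is estimated at 29000 nM with an expected range from 13000 nM to 60000 nM for now.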

Compound 4, half-maximal inhibitory concentration: "not active" (no number reported)
Compound 4 has no reported number here, and the estimate cannot be compared.
By their numbers in this assay, from the lowest: compounds 1, 2 and 3 (each within the scatter of the next).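

Going by these compounds alone, compound 4 is recorded as "not active" without a number in this assay, so no step from compound 2 to compound 4 can be read. As far as these compounds go, how far 4-cyanophenyl in place of 2,5-dimethoxyphenyl moves the value stays open, and no supporting data bear on this result.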